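Swapping the outer ring pair on a shared purine-free core

The source may report more compounds than this note shows. Statements on the series, on what has been measured and on what is new or still open speak of the compounds shown alone.

Measured compounds:
compound 1 `NC1CCC(Nc2nc(NCc3ccc(-c4ccccc4)cc3)c3ncn(C4CCCC4)c3n2)CC1` — 240 nM
compound 2 `NC1CCC(Nc2nc(NCc3ccc(-c4ccsc4)cc3)c3ncn(C4CCCC4)c3n2)CC1` — 220 nM

Of the compounds shown here, two have been tested in a functional assay on HeLa cells (Homo sapiens) for inhibition, with a stated time of 72 h; on this read-out lower numbers stand for stronger inhibition and higher numbers for weaker inhibition. Compound 1 gives 240 nM, and compound 2 gives 220 nM; the two numbers sit within the scatter of each other, so on the data shown compound 1 stands level with compound 2 rather than apart from it.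

Compound 3 `NC1CCC(Nc2nc(NCc3ccc(-c4cccs4)nc3)c3ncn(C4CCCC4)c3n2)CC1` has not been measured yet. It differs from compound 1 in one place: 6-(thiophen-2-yl)pyridin-3-yl in place of 4-phenylphenyl on a saturated chain carbon bound to a nitrogen on an aromatic ring.

For the measured compounds named here, only one measured step speaks to this change. Going a 1.1-fold lower number from compound 1 to compound 2 (0.04 log units; within the scatter), and that step exchanged a phenyl for a thiophen-3-yl, which is part of what happens here. The remaining part of the change, a nitrogen entering the six-membered ring that carries the chain, has no measured counterpart among the compounds shown.

Taken together, the step from compound 1 to compound 3 is expected to stay close to the scatter, a 1.2-fold lower number from compound 1 to compound 3 (0.08 log units; within the scatter). Compound 3 is therefore estimated at 200 nM, with a range from 80 nM to 500 nM.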

Compound 3, half-maximal inhibitory concentration: 40 nM
The estimate for compound 3 lay 5.0-fold (0.70 log units) above the measured number; the measured number lies below the stated range.
By their numbers in this assay, from the lowest: compound 3; then compounds 2 and 1 (each within the scatter of the next).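

In this assay, the exchange of one outer ring between compound 1 and compound 2 had left the number within the scatter, so this position could have seemed tolerant of change. The new result shows otherwise: replacing 4-phenylphenyl with 6-(thiophen-2-yl)pyridin-3-yl gives a 6.0-fold lower number from compound 1 to compound 3 (0.78 log units; beyond the scatter), and replacing 4-(thiophen-3-yl)phenyl with the same group gives a 5.5-fold lower number from compound 2 to compound 3 (0.74 log units; beyond the scatter), so the group on this saturated chain carbon can shift the read-out beyond the scatter. No measurement shown explains why compound 3 gives the lowest number of the three.

Each step to compound 3 changes more than one feature of the group at once, so the compounds shown leave open whether the gain comes from the nitrogen in the six-membered ring, from the thiophen-2-yl ring, or only from the two together; 6-phenylpyridin-3-yl and 4-(thiophen-2-yl)phenyl would each carry one of these features alone. Going by these compounds, it also remains open whether another five-membered ring on the pyridine, such as furan-2-yl, would keep the lower number.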